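Secondary amines versus dimethylamino at the shared core

The source may report more compounds than this note shows. Statements on the series, on what has been measured and on what is new or still open speak of the compounds shown alone.

Measured so far in an assay on CHO cells for displacement of a labelled ligand from adenosine receptor A3 (Homo sapiens); a higher number here means a weaker inhibitor, a lower number a stronger inhibitor:
compound 1 `CCOC(=O)c1cnc(NCC2CCCCC2)n2nc(-c3ccco3)nc12`, 41.2 nM
compound 2 `CCOC(=O)c1cnc(NCCOC)n2nc(-c3ccco3)nc12`, 105 nM
compound 3 `CCOC(=O)c1cnc(N(C)C)n2nc(-c3ccco3)nc12`, 275 nM

Compound 3 gives the highest number of the three, with compound 2 nearest (a 2.6-fold higher number from compound 2 to compound 3 (0.42 log units; beyond the scatter)) and compound 1 furthest (a 6.7-fold higher number from compound 1 to compound 3 (0.82 log units; beyond the scatter)). Both of these steps exchange a secondary amine bearing a chain for the dimethylamino group, and both raise the number beyond the scatter.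

Compound 4 `CCOC(=O)c1cnc(NC2CCCCC2)n2nc(-c3ccco3)nc12` reverses that kind of exchange: cyclohexylamino in place of dimethylamino on an aromatic carbon. The relevant measured steps are the two just named, which run the other way and were of modest size, so the expected direction for compound 4 in this assay is a lower number, of comparable magnitude. The closest measured analogue with a ring on the amine is compound 1, whose chain is one carbon longer; compound 2 shows a secondary amine without a ring already sits well below compound 3.

Compound 4 is therefore expected at 60 nM (range 25 nM to 150 nM), a step of a 4.6-fold lower number from compound 3 to compound 4 (0.66 log units; beyond the scatter) estimated from compound 3.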

Compound 4, inhibition constant: 131 nM
The estimate for compound 4 lay 2.2-fold (0.34 log units) below the measured number; low and high end bracket the measured number.
By their numbers in this assay, from the lowest: compound 1; then compounds 2 and 4 (each within the scatter of the next); then compound 3.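

In this assay, a cyclohexyl ring on the nitrogen does not on its own reproduce the result of compound 1: a 3.2-fold higher number from compound 1 to compound 4 (0.50 log units; beyond the scatter) when cyclohexyl replaces cyclohexylmethyl, so the methylene link between ring and nitrogen counts at this position. With a 1.2-fold higher number from compound 2 to compound 4 (0.10 log units; within the scatter), cyclohexyl and 2-methoxyethyl on that nitrogen cannot be told apart, so a ring directly on the nitrogen shows no separation from the open ether chain. The change from dimethylamino still pays with a 2.1-fold lower number from compound 3 to compound 4 (0.32 log units; beyond the scatter), making all three secondary amines shown lower in number than compound 3, with none going against this.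

Nothing available explains these differences. Open, on these data alone, are a longer link such as 2-cyclohexylethylamino, and methyl(cyclohexyl)amino, which would test the cyclohexyl ring on a tertiary amine against dimethylamino.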